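The source may report more compounds than this note shows. Statements on the series, on what has been measured and on what is new or still open speak of the compounds shown alone.

Measured so far:
compound 1, `CNc1nncc2c(C)ncn12`: in a functional assay for inhibition, with Homo sapiens as the target (on this read-out higher numbers stand for weaker inhibition and lower numbers for stronger inhibition), compound 1 gives > 48000 nM, which is a limit of the assay and not a number.
compound 2, `CCCc1nc(C)c2cnn(CC(=O)OCC)c(=O)n12`: in this assay compound 2 gives > 48000 nM, likewise a limit.

Compound 1 stands at the limit, and both shown values sit at the limit of > 48000 nM in this assay, at which 2 of the 2 values shown sit. Going by the values given here, nothing measured joins compound 1 and compound 2 by a single change, so no measured step is available.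

The next compound is compound 3, `Cc1ncn2c(NN)nncc12`. It differs from compound 1 in one place: amino in place of methyl on a nitrogen on an aromatic ring. The methyl leaves and an amino enters on the nitrogen on the aromatic ring; cut one bond further out, the change reads methylamino to aminoamino.

With every measured value sitting at the limit, no direction is indicated. The step that the limit leaves unreadable from compound 1 to compound 3 is expected to be none beyond the scatter. Compound 3 is therefore estimated at 60000 nM, between 15000 nM and 250000 nM, most likely again reported only as a limit.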

Compound 3, half-maximal inhibitory concentration: > 48000 nM
Compound 3 ended at the assay's limit; the forecaster's own chance of this, stated with the estimate: 85%; the middle value lies beyond the limit too.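

Compound 1 and compound 3 give no readable step in this assay, since both stand at a limit of the assay: the limit of > 48000 nM in this assay, at which 3 of the 3 values shown sit.

Open: whether amino in place of methyl changes inhibition at all, in which direction, and which change to the shared core would give a value short of the limit.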